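The compounds below may be only part of what the source reports. "The series", "measured", "known", "first", "only" and "open" are said of these compounds alone.

Compound 1 `COc1cc(CC(O)c2ccc(-c3ccc([N+](=O)[O-])cc3)cc2)c([N+](=O)[O-])cc1OC` gives 21000 nM
Compound 2 `COc1cc(CC(O)c2ccc(-c3ccc(F)cc3)cc2)c([N+](=O)[O-])cc1OC` gives 4500 nM
Compound 3 `COc1cc(CC(O)c2ccc(-c3cccc(C#N)c3)cc2)c([N+](=O)[O-])cc1OC` gives 5200 nM

These numbers come from an ADME assay on HeLa Rh cells (Homo sapiens) for cytotoxicity, read by microscopy (a lower number here means that less compound is tolerated, a higher number that more compound is tolerated), as the only test so far. Compound 3 stands second of the three, yet level with its nearest neighbour (a 1.2-fold higher number from compound 2 to compound 3 (0.06 log units; within the scatter)). Compound 1 alone stands apart (a 4.0-fold lower number from compound 1 to compound 3 (0.61 log units; beyond the scatter)) and (a 4.7-fold lower number from compound 1 to compound 2 (0.67 log units; beyond the scatter)). Compound 4 `COc1cc(CC(O)c2ccc(-c3cccc(F)c3)cc2)c([N+](=O)[O-])cc1OC` differs from compound 3 as follows: fluoro in place of cyano on an aromatic carbon. This puts fluoro in place of cyano, meta to a large group. Among the measured compounds shown here, no measured step makes this exact swap. The closest one, from 4-fluorophenyl to 3-cyanophenyl, stayed within the scatter (a 1.2-fold higher number from compound 2 to compound 3 (0.06 log units; within the scatter)). So no step beyond the scatter is expected in this assay (a 1.1-fold lower number from compound 3 to compound 4 (0.03 log units; within the scatter)). Compound 4 is estimated at 4800 nM with an expected range from 2500 nM to 9500 nM as the likely span.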

Compound 4, half-maximal cytotoxic concentration: 7400 nM
The estimate for compound 4 lay 1.5-fold (0.19 log units) below the measured number, within the range that was stated.
By their numbers in this assay, from the lowest: compounds 2, 3 and 4 (each within the scatter of the next); then compound 1.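

In this assay, fluoro in place of the nitrile leaves the number within the scatter (a 1.4-fold higher number from compound 3 to compound 4 (0.15 log units; within the scatter)), as does 3-fluorophenyl in place of 4-fluorophenyl (a 1.6-fold higher number from compound 2 to compound 4 (0.22 log units; within the scatter)), so compound 2, compound 3 and compound 4 stay level. Compound 1 still stands apart, and 3-fluorophenyl in place of its 4-nitrophenyl gives a step beyond the scatter (a 2.8-fold lower number from compound 1 to compound 4 (0.45 log units; beyond the scatter)). No measurement shown explains these results. The compounds shown leave open whether an amine or a carboxylic acid in place of the fluoro would stay level with compound 4. They also leave open whether a nitro group at this position would bring the number closer to that of compound 1.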